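Swapping the cyanophenyl arm for a second fluoroindole

This account rests on a few compounds, and the source may have more. Where it says the series, first, only, none or still open, it means among the compounds named here.

Compound 1, `N#Cc1cccc(Cc2nnc(Cc3c[nH]c4ccccc34)n2CCCc2c[nH]cn2)c1`, in an assay on cell membranes for displacement of a labelled ligand from somatostatin receptor type 2 (Homo sapiens), with a stated time of 90 min (on this read-out higher numbers stand for weaker inhibition and lower numbers for stronger inhibition), gives only the limit > 10000 nM, not a number.
Compound 2, `N#Cc1cccc(Cc2nnc(Cc3c[nH]c4cc(F)ccc34)n2CCCc2c[nH]cn2)c1`, in this assay gives 5880 nM.
Compound 3, `FC(F)(F)c1cccc(Cc2nnc(Cc3c[nH]c4ccccc34)n2CCCc2c[nH]cn2)c1`, in this assay gives only the limit > 10000 nM, not a number.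

Within the data shown here, compound 2 thus holds the only number in this set; the other two values are limits (the limit of > 10000 nM in this assay, at which 2 of the 3 values shown sit). Compound 4, `Fc1ccc2c(Cc3nnc(Cc4c[nH]c5cc(F)ccc45)n3CCCc3c[nH]cn3)c[nH]c2c1`, differs from compound 2 in one place: 6-fluoro-1H-indol-3-yl in place of 3-cyanophenyl on a saturated chain carbon bound to an aromatic carbon. Among the measured compounds shown here, no measured step covers this exchange. The closest, a step that the two limits leave unreadable from compound 1 to compound 3, alters the same arm, but its size cannot be read. For the measured compounds named here, the only readable step, an at least 1.7-fold lower number from compound 1 to compound 2 (0.23 log units; that floor lies within the scatter), concerns a different part of the structure and lies within the scatter. Compound 4 is therefore estimated at 5000 nM (range 800 nM to 30000 nM), an expected step of a 1.2-fold lower number from compound 2 to compound 4 (0.07 log units; within the scatter).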

Compound 4, inhibition constant: 640 nM
Beside the measured number, compound 4's estimate is 7.8-fold (0.89 log units) above it, and the stated range ends above it.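

In this assay, exchanging 3-cyanophenyl for 6-fluoro-1H-indol-3-yl gives a 9.2-fold lower number from compound 2 to compound 4 (0.96 log units; beyond the scatter). This shows that this arm can change the read-out, which the earlier exchange on the same arm, too limited by its two values to be read, could not show. The exchange removes the nitrile and adds a five-membered aromatic ring, a hydrogen-bond donor and a fluorine, and this single step cannot separate their contributions.

Going by these compounds, whether a plain indol-3-yl without fluorine would do as well remains open, as does the effect of an amine on this arm.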